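Replacing the bromopyridine of compound 2 with a methylpyridine

This account rests on a few compounds, and the source may have more. Where it says the series, first, only, none or still open, it means among the compounds named here.

In a functional assay on WM 266-4 cells (Homo sapiens) for antiproliferative activity, read by MTT assay, with a stated time of 24 h (on this read-out higher numbers stand for weaker inhibition of growth and lower numbers for stronger inhibition of growth), compound 2 (`COc1ccc(C2=NN(C(=O)c3cncc(Br)c3)C(c3ccc(Cl)cc3)C2)cc1`) gives 1290 nM and compound 3 (`COc1ccc(C2=NN(C(=O)c3ccc(C)nc3Cl)C(c3ccc(Cl)cc3)C2)cc1`) gives 1440 nM within the scatter of it, while compound 1 (`COc1ccc(C2=NN(C(=O)c3cccnc3Cl)C(c3ccc(OC)cc3)C2)cc1`) stands higher at 4350 nM on the same read-out. Compound 4 (`COc1ccc(C2=NN(C(=O)c3ccc(C)nc3)C(c3ccc(Cl)cc3)C2)cc1`) is not yet measured. Its change from compound 2 is 6-methylpyridin-3-yl in place of 5-bromopyridin-3-yl on a carbonyl carbon and puts 6-methylpyridin-3-yl in place of 5-bromopyridin-3-yl on a carbonyl carbon. Within the data shown here, the only measured step at this place is a 1.1-fold higher number from compound 2 to compound 3 (0.05 log units; within the scatter) and it stays within the scatter, so no step beyond the scatter is expected in this assay here. For compound 4 the estimated step is a 1.2-fold higher number from compound 2 to compound 4 (0.07 log units; within the scatter) on this reading. Compound 4 is estimated at 1500 nM with a range of 650 nM to 3500 nM in this series.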

Compound 4, concentration for 50% growth inhibition: 890 nM
Beside the measured number, compound 4's estimate is 1.7-fold (0.23 log units) above it; the measured number falls inside the stated range.
By their numbers in this assay, from the lowest: compounds 4, 2 and 3 (each within the scatter of the next); then compound 1.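

On a carbonyl carbon whose other neighbour is the amide-type nitrogen in a ring, 6-methylpyridin-3-yl in place of 5-bromopyridin-3-yl gives a 1.4-fold lower number from compound 2 to compound 4 (0.16 log units; within the scatter) in this assay, so a second group at this place reads level with the bromo compound. Hydrogen in place of chloro on an aromatic carbon gives a 1.6-fold lower number from compound 3 to compound 4 (0.21 log units; within the scatter), so the chloro group of compound 3 makes no readable difference here. No available evidence bears on these results. Open, going by these compounds, is whether an amine, a carboxylic acid or a longer chain in place of the methyl of 6-methylpyridin-3-yl would give a step beyond the scatter.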